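The source may hold more compounds than are shown below. What is called first, only, known or untested is meant among the compounds shown, and "the series" means these compounds.

Compound 1 `CCOC(=O)c1oc2ccc(NS(=O)(=O)c3ccccc3Cl)cc2c1C` carries a 2-chlorophenyl on the sulfonyl sulfur. In a functional assay on MDA-MB-231 cells (Homo sapiens) for antiproliferative activity, read by MTT assay, with a stated time of 72 h (a lower number here means a stronger inhibitor, a higher number a weaker inhibitor), compound 1 reaches only the assay limit > 200000 nM. For the measured compounds named here, compound 2 `CCOC(=O)c1oc2ccc(NS(=O)(=O)c3cccc([N+](=O)[O-])c3)cc2c1C` bears a 3-nitrophenyl at the same place; in this assay compound 2 gives 59900 nM, the only finite number in the set. The step of an at least 3.3-fold lower number from compound 1 to compound 2 (0.52 log units; beyond the scatter) rests on the limit (the limit of > 200000 nM in this assay, at which 1 of the 2 values shown sits). Compound 3 `CCOC(=O)c1oc2ccc(NS(=O)(=O)c3ccccc3[N+](=O)[O-])cc2c1C` differs from compound 2 by 2-nitrophenyl in place of 3-nitrophenyl on a sulfonyl sulfur. Going by the values given here, only that one bounded step bears on the change, so for compound 3 a weaker number is expected, a 1.8-fold higher number from compound 2 to compound 3 (0.26 log units; within the scatter), with a fair chance of another limit. Compound 3 is therefore estimated at 110000 nM, between 40000 nM and 250000 nM.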

Compound 3, half-maximal inhibitory concentration: 80400 nM
Compound 3: the middle estimate sits 1.4-fold (0.14 log units) above what was measured, and the stated range covers the measured number.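

In this assay, 2-nitrophenyl in place of 3-nitrophenyl on the sulfonyl sulfur gives a 1.3-fold higher number from compound 2 to compound 3 (0.13 log units; within the scatter), so these two nitrophenyl groups cannot be told apart here. Nitro in place of chloro on an aromatic carbon, a comparison that the earlier pair did not allow, gives an at least 2.4-fold lower number from compound 1 to compound 3 (0.39 log units; beyond the scatter). This step is only a bound, as compound 1 stands at a limit: the limit of > 200000 nM in this assay, at which 1 of the 3 values shown sits.

Still open, as far as these compounds go, is whether an amine or a carboxylic acid in place of the nitro group would shift the number beyond the scatter. The compounds shown also leave open how any group other than a substituted phenyl would behave on the sulfonyl sulfur.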